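The source may report more compounds than this note shows. Statements on the series, on what has been measured and on what is new or still open speak of the compounds shown alone.

Measured compounds:
compound 1 `CCC(CC)O[C@@H]1C=C(C(=O)O)C[C@H](NCc2ccc(C(C)(C)C)cc2)[C@H]1NC(C)=O`: > 200000 nM in an ADME assay on cells (Fibroblast, Gallus gallus) for cytotoxicity, read by CCK-8 assay, with a stated time of 48 h (on this read-out lower numbers stand for higher toxicity in this test and higher numbers for lower toxicity in this test), a limit
compound 2 `CCC(CC)O[C@@H]1C=C(C(=O)O)C[C@H](NCc2ccc(OC(C)C)cc2)[C@H]1NC(C)=O`: > 200000 nM in this assay, a limit
compound 3 `CCC(CC)O[C@@H]1C=C(C(=O)O)C[C@H](NCc2ccc(SCC(C)C)cc2)[C@H]1NC(C)=O`: > 200000 nM in this assay, a limit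

In this assay compound 1 stands only at a limit, not at a number. The same holds for compound 2 and for compound 3, so every value here sits at the limit of > 200000 nM in this assay, at which 3 of the 3 values shown sit. Compound 4 `CCC(CC)O[C@@H]1C=C(C(=O)O)C[C@H](NCc2ccc(S(=O)(=O)c3ccccc3)cc2)[C@H]1NC(C)=O` differs from compound 1 by phenylsulfonyl in place of tert-butyl on an aromatic carbon. The steps a step that the two limits leave unreadable from compound 1 to compound 2, a step that the two limits leave unreadable from compound 1 to compound 3 and a step that the two limits leave unreadable from compound 2 to compound 3 are all unreadable because of the limit of > 200000 nM in this assay, at which 3 of the 3 values shown sit, so no size or direction can be taken from them. With nothing readable, compound 4 is expected to stand at that limit as well, the estimated step being a number no higher from compound 1 to compound 4 (the limit leaves the size open). The estimate for compound 4 is 200000 nM, between 100000 nM and 400000 nM.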

Compound 4, half-maximal cytotoxic concentration: > 200000 nM
Compound 4 was reported as a limit (the forecaster's own chance of this, stated with the estimate: 80%); the middle value lies on the limit itself.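

No step can be read among compound 1, compound 2, compound 3 and compound 4, because each stands only at a limit: the limit of > 200000 nM in this assay, at which 4 of the 4 values shown sit. The compounds shown leave open how far their true values in this assay lie beyond that limit, and whether these groups differ at all.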